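The compounds below may be only part of what the source reports. "The series", "measured", "known", "first", "only" and "open" are said of these compounds alone.

Two compounds that share one core have numbers in a functional assay on MDA-MB-231 cells (Homo sapiens) for antiproliferative activity, read by MTT assay, with a stated time of 48 h; a higher number here means a weaker inhibitor, a lower number a stronger inhibitor. Among the measured compounds shown here, compound 1 `C=CS(=O)(=O)N1CCN(c2ncnc3sc(-c4ccc(C#N)cc4)cc23)CC1` gives 8050 nM, the lowest number so far and a gap beyond the scatter from compound 2 `C=CS(=O)(=O)N1CCN(c2ncnc3sc(-c4cn(S(=O)(=O)c5ccccc5)c5ccccc45)cc23)CC1`, which gives 40400 nM. Compound 3 `C=CS(=O)(=O)N1CCN(c2ncnc3sc(-c4cn(C)nc4C(F)(F)F)cc23)CC1` keeps the core of compound 1 and changes one group: 1-methyl-3-(trifluoromethyl)-1H-pyrazol-4-yl in place of 4-cyanophenyl on an aromatic carbon, next to the ring sulfur (1-methyl-3-(trifluoromethyl)-1H-pyrazol-4-yl in place of 4-cyanophenyl on an aromatic carbon). For the measured compounds named here, no measured pair isolates a single change, so this forecast is loose. Going by the values given here, the only other group measured, in compound 2 at 40400 nM, gives a higher number, which tilts the expectation slightly upward. In this assay, a small rise that stays within the scatter is expected, and the estimated move is a 1.5-fold higher number from compound 1 to compound 3 (0.17 log units; within the scatter). For compound 3, the expected value is 12000 nM, with an estimated range of 4000 nM to 36000 nM.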

Compound 3, half-maximal inhibitory concentration: 10400 nM
Estimate against measurement, compound 3: 1.2-fold (0.06 log units) above, and the stated range covers the measured number.
By their numbers in this assay, from the lowest: compounds 1 and 3 (each within the scatter of the next); then compound 2.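

In this assay, replacing the six-membered, all-carbon 4-cyanophenyl with the five-membered 1-methyl-3-(trifluoromethyl)-1H-pyrazol-4-yl gives a 1.3-fold higher number from compound 1 to compound 3 (0.11 log units; within the scatter). This position, on an aromatic carbon next to the ring sulfur, can therefore carry either ring with no difference that stands out from the scatter, and in this one pair the nitrile can leave without a readable shift in the number. Nothing available explains why these two groups read alike.

From the compounds shown here alone, it remains open whether a group of another kind at this position, such as a carboxylic acid or a simple amine, would move the number beyond the scatter. Also open, going by these compounds, is what the methyl and the trifluoromethyl on the pyrazole each contribute on their own.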